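Swapping a benzyl group for a thiourea on a weak scaffold

The source may report more compounds than this note shows. Statements on the series, on what has been measured and on what is new or still open speak of the compounds shown alone.

Measured so far:
- compound 1 `NC(=O)c1c(NC(=O)c2ccccc2Cl)sc2c1CCN(Cc1ccc(Cl)cc1)C2`: 18700 nM
- compound 2 `NC(=O)c1c(NC(=O)c2ccccc2Cl)sc2c1CCN(Cc1cc(Cl)cc(Cl)c1)C2`: 23700 nM

In a functional assay on MKN-74 cells (Homo sapiens) for antiproliferative activity, with a stated time of 24 h (on this read-out higher numbers stand for weaker inhibition and lower numbers for stronger inhibition), compound 1 gives 18700 nM, and compound 2 gives 23700 nM. Among the compounds with values here, compound 2 carries the highest of the two numbers, but the only measured step, a 1.3-fold higher number from compound 1 to compound 2 (0.10 log units; within the scatter), lies within the scatter, so the two compounds cannot be told apart on this read-out. Both are weak inhibitors.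

Compound 3 `NC(=O)c1c(NC(=O)c2ccccc2Cl)sc2c1CCN(C(=S)Nc1ccccc1F)C2` departs from compound 2 by a different kind of change: a group of 10 heavy atoms (7 carbon, 1 nitrogen, 1 fluorine, 1 sulfur; one six-membered aromatic ring of carbon only) in place of a group of 9 heavy atoms (7 carbon, 2 chlorine; one six-membered aromatic ring of carbon only), on an amine nitrogen in a ring. The entering group brings a hydrogen-bond donor and a hydrogen-bond acceptor and a double bond outside aromatic rings, where the leaving 3,5-dichlorobenzyl had none. Within the data shown here, the single measured step concerned only a change of substitution on an aromatic ring and left the number almost unchanged; no measured step covers an exchange of this sort, so there is no basis for expecting a large move in either direction.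

Compound 3 is therefore expected to give about 20000 nM in this assay, with a likely range from 5000 nM to 80000 nM, which means an expected step of a 1.2-fold lower number from compound 2 to compound 3 (0.07 log units; within the scatter).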

Compound 3, half-maximal inhibitory concentration: 12600 nM
Compound 3: the middle estimate sits 1.6-fold (0.20 log units) above what was measured; the measured number falls inside the stated range.
By their numbers in this assay, from the lowest: compounds 3, 1 and 2 (each within the scatter of the next).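

On the amine nitrogen in a ring, this assay now covers a far larger exchange than a change of substitution on an aromatic ring: putting the fluorophenyl thiourea group in place of the 3,5-dichlorobenzyl gives a 1.9-fold lower number from compound 2 to compound 3 (0.27 log units; within the scatter), and the same kind of exchange against the monochlorinated benzyl group gives a 1.5-fold lower number from compound 1 to compound 3 (0.17 log units; within the scatter). Both steps lie within the scatter, so a new link to the ring, together with a double bond outside aromatic rings and a hydrogen-bond donor and acceptor, does not separate these three compounds on this read-out. Nothing available explains this result or bears on it.

The compounds shown leave open whether a different kind of group on this nitrogen, such as an acetyl group or a urea with oxygen in place of the sulfur, would move the number beyond the scatter. They also leave open what a methoxy group in place of the fluorine on the thiourea's aromatic ring would do, and whether changes elsewhere on the shared core matter more than this position.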